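Amide nitrogen substituent change: 4-fluorobenzyl to 4-fluorophenyl

The source may hold more compounds than are shown below. What is called first, only, known or untested is meant among the compounds shown, and "the series" means these compounds.

Compound 1 `COc1ccc2c(=O)c(/C=C/C(=O)Nc3ccccc3)coc2c1` carries a phenyl on the amide-type nitrogen of the shared core, and in a functional assay on Huh-7 cells (Homo sapiens) for inhibition, read by MTT assay, with a stated time of 48 h (a lower number here means a stronger inhibitor, a higher number a weaker inhibitor), compound 1 gives 9050 nM. Among the measured compounds shown here, compound 2 `COc1ccc2c(=O)c(/C=C/C(=O)NCc3ccc(F)cc3)coc2c1` carries a 4-fluorobenzyl in that place; in this assay compound 2 gives 21000 nM, the higher of the two numbers measured so far. The step of a 2.3-fold higher number from compound 1 to compound 2 (0.37 log units; beyond the scatter) is the only measured one available.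

Compound 3 `COc1ccc2c(=O)c(/C=C/C(=O)Nc3ccc(F)cc3)coc2c1` differs from compound 2 by 4-fluorophenyl in place of 4-fluorobenzyl on an amide-type nitrogen. This removes the one-carbon link between the amide-type nitrogen and the ring, which is the main part of what the step from compound 1 to compound 2 introduced, while the fluorine is kept. The step to compound 3 is therefore expected to run back toward compound 1, roughly as large as a 2.3-fold higher number from compound 1 to compound 2 (0.37 log units; beyond the scatter) but in the opposite direction, so a 2.2-fold lower number from compound 2 to compound 3 (0.34 log units; beyond the scatter) is expected. For compound 3 in this assay the estimate is 9500 nM, within 4000 nM to 22000 nM.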

Compound 3, half-maximal inhibitory concentration: 33900 nM
Compound 3: middle estimate off by 3.6-fold (0.55 log units), on the low side; the measured number lies above the stated range.
By their numbers in this assay, from the lowest: compound 1; then compounds 2 and 3 (each within the scatter of the next).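

In this assay the step that removes the one-carbon link while keeping the fluorine (a 1.6-fold higher number from compound 2 to compound 3 (0.21 log units; within the scatter)) does not separate 4-fluorobenzyl from 4-fluorophenyl on the amide-type nitrogen, so the link alone is not shown to matter here. The step that registers is on the ring, with fluoro in place of hydrogen on an aromatic carbon (a 3.7-fold higher number from compound 1 to compound 3 (0.57 log units; beyond the scatter)), and this leaves the unsubstituted phenyl of compound 1 with the lowest number of the three. No measurement in hand accounts for this result.

Going by these compounds, it remains open whether the fluoro step carries over to an unsubstituted benzyl on the same nitrogen. Also open, on these data alone, is how chloro or methoxy in place of the fluoro, or a longer chain such as 2-phenylethyl, would read in this assay.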